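This account rests on a few compounds, and the source may have more. Where it says the series, first, only, none or still open, it means among the compounds named here.

Two compounds built on a shared core, compound 1 `Nc1nc(Cl)nc2c1ncn2[C@@H]1O[C@H]([C@H](O)CO)[C@@H](O)[C@H]1O` and compound 2 `CNc1ncnc2c1ncn2[C@@H]1O[C@H]([C@H](O)CO)[C@@H](O)[C@H]1O`, were tested in a functional assay on HeLa cells (Homo sapiens), read by colorimetric assay, with a stated time of 48 h; a lower number here means a stronger inhibitor, a higher number a weaker inhibitor. Compound 1 gives > 100000 nM, which is a limit of the assay and not a number. Compound 2 gives > 100000 nM, which is again only a limit. The whole picture so far is the limit of > 100000 nM in this assay, at which 2 of the 2 values shown sit, so compound 2 has no number against which a step can be measured.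

Compound 3 `CNc1nc(Cl)nc2c1ncn2[C@@H]1O[C@H]([C@H](O)CO)[C@@H](O)[C@H]1O` has not yet been measured. It differs from compound 2 by one change: chloro in place of hydrogen on an aromatic carbon. For the measured compounds named here, no measured pair shows the size of this change in this assay, so the expectation rests on little. The most likely result is that compound 3 is also reported only as a limit, and no step beyond the usual scatter is expected in either direction. The expected step, a number no higher from compound 2 to compound 3 (the limit leaves the size open), is therefore none that the assay could resolve. Compound 3 is estimated at 100000 nM, with an expected range from 30000 nM to 300000 nM.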

Compound 3, half-maximal inhibitory concentration: > 100000 nM
Compound 3 gave a limit, no number; the forecaster's own chance of this, stated with the estimate: 75%; the middle value lies on the limit itself.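

In this assay compound 3 gives > 100000 nM, which is a limit and not a number. The steps to compound 3 from compound 1 and compound 2 therefore cannot be read: the limit of > 100000 nM in this assay, at which 3 of the 3 values shown sit. The compounds shown leave open what effect, if any, chloro in place of hydrogen on an aromatic carbon or methyl in place of hydrogen on a nitrogen on an aromatic ring has on inhibition.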